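The source may hold more compounds than are shown below. What is called first, only, known or untested is meant among the compounds shown, and "the series" means these compounds.

Compound 1 `O=C(CSc1nccn1-c1ccc(Cl)cc1)Nc1ccccc1[N+](=O)[O-]`: > 321000 nM (a limit)
Compound 2 `Cc1ccc(-n2ccnc2SCC(=O)Nc2ccccc2[N+](=O)[O-])cc1`: 131000 nM

Among the compounds with values here, in an ADME assay on MT4 cells (Homo sapiens) for cytotoxicity, read by MTT assay (a higher number here means that more compound is tolerated, a lower number that less compound is tolerated), compound 2 gives 131000 nM, the only true number so far. Compound 1 gives > 321000 nM, which is a limit of the assay. Compound 3 `Cc1ccc(-n2ccnc2SCC(=O)Nc2ccccc2Cl)cc1` has chloro in place of nitro on an aromatic carbon, ortho to a large group: chloro in place of nitro on an aromatic carbon. Within the data shown here, the sole measured step, an at least 2.4-fold lower number from compound 1 to compound 2 (0.38 log units; beyond the scatter), was modest and lies at a different place, so it offers only a loose guide. A small change is therefore expected, perhaps slightly downward, as the estimated 1.3-fold lower number from compound 2 to compound 3 (0.12 log units; within the scatter) shows. The estimate for compound 3 is 100000 nM, with an expected range of 30000 nM to 300000 nM.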

Compound 3, half-maximal cytotoxic concentration: 33700 nM
For compound 3 the middle estimate is 3.0-fold (0.47 log units) above the measured one; the range from low to high includes it.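

Putting chloro in place of nitro on the aromatic carbon ortho to a large group gives a 3.9-fold lower number from compound 2 to compound 3 (0.59 log units; beyond the scatter) in this assay, so less compound is tolerated with chloro there. A single change at this position therefore moves the number, and not only a change at the place of the earlier step. This step joins two true numbers, so its full size can be read, whereas the earlier step rests on a limit: the limit of > 321000 nM in this assay, at which 1 of the 3 values shown sits.

From the compounds shown here alone, how an amine or a methoxy group at this position would compare remains open. Also open, going by these compounds, is whether the same swap would give a similar step with chloro in place of the methyl.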